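A Pyridin-2-yl Group Enters Where Methyl Stood

The source may hold more compounds than are shown below. What is called first, only, known or untested is meant among the compounds shown, and "the series" means these compounds.

Compound 1 `C/C(=N\Nc1nc(C)cs1)c1ccc(Cl)c(Cl)c1` was tested in an ADME assay on J774 cells (Mus musculus) for cytotoxicity, read by resazurin assay, with a stated time of 72 h (a higher number here means that more compound is tolerated, a lower number that less compound is tolerated), and gives 33700 nM. Within the data shown here, its only measured companion is compound 2 `C/C(=N\Nc1nc(C)c(C)s1)c1ccc(Cl)c(Cl)c1`, which in this assay gives 41800 nM. Among the measured compounds shown here, the single measured step, a 1.2-fold higher number from compound 1 to compound 2 (0.09 log units; within the scatter), lies within the scatter, so compound 1 stands alongside compound 2 rather than apart from it, and the two numbers cannot be told from one another.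

Compound 3 `C/C(=N\Nc1nc(-c2ccccn2)cs1)c1ccc(Cl)c(Cl)c1` has not yet been measured. It differs from compound 1 in one place: pyridin-2-yl in place of methyl on an aromatic carbon. For the measured compounds named here, no measured step bears directly on this exchange. Going by the values given here, the one step that exists, a 1.2-fold higher number from compound 1 to compound 2 (0.09 log units; within the scatter), concerns a different group entering at another aromatic carbon of the same core and stayed within the scatter, so it gives neither a direction nor a size for a larger group at this position. The step from compound 1 to compound 3 is therefore expected to be a 1.3-fold lower number from compound 1 to compound 3 (0.13 log units; within the scatter), with no clear direction beyond the scatter. Compound 3 is estimated at 25000 nM, within a range from 8000 nM to 70000 nM.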

Compound 3, half-maximal cytotoxic concentration: 10100 nM
Beside the measured number, compound 3's estimate is 2.5-fold (0.39 log units) above it; low and high end bracket the measured number.
By their numbers in this assay, from the lowest: compound 3; then compounds 1 and 2 (each within the scatter of the next).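

In this assay, among these compounds, the exchange at this position, on an aromatic carbon next to the ring nitrogen, gives the first step beyond the scatter: a 3.3-fold lower number from compound 1 to compound 3 (0.52 log units; beyond the scatter). The earlier step, a 1.2-fold higher number from compound 1 to compound 2 (0.09 log units; within the scatter), concerned methyl in place of hydrogen at another aromatic carbon and could not be told from repeated measurement, so it showed no movement in either direction. Pyridin-2-yl in place of methyl now shows that the number can move with a change on the shared core, and that it moves towards less compound being tolerated, although the step is modest. Nothing measured here explains this step.

The compounds shown leave open whether the lower number goes with the aromatic ring itself or with its ring nitrogen, a question that a phenyl group at the same carbon would address. They also leave open how a group of another kind, such as an amine or a carboxylic acid, would read at this position, and whether a longer chain would follow pyridin-2-yl or stay with methyl.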